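Compound 3 and the Step to an Ethyl Group

The compounds below may be only part of what the source reports. "The series", "measured", "known", "first", "only" and "open" are said of these compounds alone.

Compound 1 `Cc1ccc(NS(=O)(=O)c2ccc(N3CCNC3=O)cc2)cc1`: 610 nM
Compound 2 `Cc1ccc(NS(=O)(=O)c2ccc(N3CCNC3=O)cc2)cc1C`: 230 nM
Compound 3 `O=C1NCCN1c1ccc(S(=O)(=O)Nc2ccc(F)c(F)c2)cc1`: 620 nM

All three values come from a functional assay on MCF7 cells (Homo sapiens) for antiproliferative activity, read by sulforhodamine B assay, with a stated time of 48 h; a higher number here means a weaker inhibitor, a lower number a stronger inhibitor. Swapping the 4-methylphenyl group for the 3,4-difluorophenyl group changes little, a 1.0-fold higher number from compound 1 to compound 3 (0.01 log units; within the scatter). Swapping the 3,4-dimethylphenyl group for it matters more, a 2.7-fold higher number from compound 2 to compound 3 (0.43 log units; beyond the scatter).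

Compound 4 `CCc1cccc(NS(=O)(=O)c2ccc(N3CCNC3=O)cc2)c1` carries 3-ethylphenyl in place of 3,4-difluorophenyl on a sulfonamide nitrogen. Going by the values given here, no measured compound has an ethyl group, so the nearest guide is the added methyl, a 2.7-fold lower number from compound 1 to compound 2 (0.42 log units; beyond the scatter). That modest step suggests a small move towards a lower number, and the expected step is a 1.6-fold lower number from compound 3 to compound 4 (0.19 log units; within the scatter). For compound 4 the estimated value is 400 nM, with an expected range of 170 nM to 950 nM.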

Compound 4, half-maximal inhibitory concentration: 130 nM
For compound 4 the middle estimate is 3.1-fold (0.49 log units) above the measured one; measured number below the stated range.
By their numbers in this assay, from the lowest: compounds 4 and 2 (each within the scatter of the next); then compounds 1 and 3 (each within the scatter of the next).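

Replacing 3,4-difluorophenyl with 3-ethylphenyl on the sulfonamide nitrogen gives the largest step seen so far (a 4.8-fold lower number from compound 3 to compound 4 (0.68 log units; beyond the scatter)), and the step from 4-methylphenyl is similar in size (a 4.7-fold lower number from compound 1 to compound 4 (0.67 log units; beyond the scatter)). Against 3,4-dimethylphenyl, the new group makes no clear difference (a 1.8-fold lower number from compound 2 to compound 4 (0.25 log units; within the scatter)). No available evidence explains these results. The compounds shown leave open how a longer chain, such as propyl, would behave at this position. They also leave open the effect of an amine or a carboxylic acid on this phenyl ring.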